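Swapping Two Chain Centres in a Platelet Inhibitor

A few compounds are considered here, and "the series" means these few. Any claim that something is new, unique, unknown or untested is made for them only; others in the source may bear on it.

Going by the values given here, compound 1 `CCCC[C@H](OC(=O)CN1CCN(C)CC1)c1ccccc1C(=O)O[C@H]1CO[C@H]2[C@@H]1OC[C@H]2OC(=O)c1ccccc1[C@H](CCCC)OC(=O)CN1CCN(C)CC1` gives the lower of the two numbers measured so far: in a functional assay on cells (Platelet, Oryctolagus cuniculus) for inhibition, read by turbidimetry, with a stated time of 5 min (on this read-out higher numbers stand for weaker inhibition and lower numbers for stronger inhibition), compound 1 gives 50000 nM, while compound 2 `CCCC[C@@H](OC(=O)CN1CCCC1)c1ccccc1C(=O)O[C@H]1CO[C@H]2[C@@H]1OC[C@H]2OC(=O)c1ccccc1[C@@H](CCCC)OC(=O)CN1CCCC1` gives 910000 nM in this assay, a gap beyond the scatter. Compound 3 `CCCC[C@@H](OC(=O)CN1CCN(C)CC1)c1ccccc1C(=O)O[C@H]1CO[C@H]2[C@@H]1OC[C@H]2OC(=O)c1ccccc1[C@@H](CCCC)OC(=O)CN1CCN(C)CC1` has not yet been measured; it differs from compound 1 only in configuration: the two compounds have the same atoms and bonds and differ only in configuration as drawn: 2 of 6 stereo elements differ; a stereocentre at a saturated chain carbon is drawn S in compound 1 and R in compound 3; a stereocentre at a saturated chain carbon is drawn S in compound 1 and R in compound 3. Among the compounds with values here, no measured pair differs in this way alone, so the size of the step is uncertain. Inverting these two centres is expected to weaken inhibition, a step in this assay of a 4.0-fold higher number from compound 1 to compound 3 (0.60 log units; beyond the scatter) towards a higher number. Compound 3 is estimated at 200000 nM, with a range from 50000 nM to 900000 nM.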

Compound 3, half-maximal inhibitory concentration: 270000 nM
Estimate against measurement, compound 3: 1.4-fold (0.13 log units) below; low and high end bracket the measured number.
By their numbers in this assay, from the lowest: compound 1; then compound 3; then compound 2.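

In this assay, going by these compounds alone, inverting the two chain centres gives a 5.4-fold higher number from compound 1 to compound 3 (0.73 log units; beyond the scatter), the first direct reading of what configuration at these positions is worth. The step is modest, yet it shows that the chain centres alone can shift inhibition. It can be assigned to configuration because nothing else separates the pair: the fact that compounds 1 and 3 differ only in the configuration as drawn

Going by these compounds, both centres change together here, so the share of each remains open. Also open, on these data alone, is whether the S centres would still give the lower number with a dimethylamino group in place of the amine ring.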